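A few compounds are considered here, and "the series" means these few. Any claim that something is new, unique, unknown or untested is made for them only; others in the source may bear on it.

Compound 1 `Nc1cc(N)c2nc(-c3ccccc3)c(Oc3ccc(Cl)c(Cl)c3)nc2c1`: in a functional assay on SK-OV-3 cells (Homo sapiens) for inhibition, read by sulforhodamine B assay, with a stated time of 48 h (on this read-out higher numbers stand for lower toxicity in this test and lower numbers for higher toxicity in this test), compound 1 gives < 100000 nM, a limit of the assay.
Compound 2 `CCOC(=O)[C@H](CCC(=O)O)NC(=O)c1ccc(Sc2nc3cc(N)cc(N)c3nc2-c2ccccc2)cc1`: in this assay compound 2 gives < 100000 nM, again a limit.
Compound 3 `CCOC(=O)[C@H](CCC(=O)O)NC(=O)c1ccc(Oc2nc3cc(N)cc(N)c3nc2-c2ccccc2)cc1`: in this assay compound 3 gives < 100000 nM, also a limit.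

Compound 1 therefore stands at the limit of < 100000 nM in this assay, at which 3 of the 3 values shown sit, so no number places it relative to the others. Compound 4 `Nc1cc(N)c2nc(-c3ccccc3)c(Oc3ccc(F)cc3)nc2c1` differs from it in one place: 4-fluorophenyl in place of 3,4-dichlorophenyl on an oxygen on an aromatic ring. Among the compounds with values here, no step between measured compounds is available here, so the size of this change has not been seen. He expects the step from compound 1 to compound 4 in this assay to be a step that the limit leaves unreadable from compound 1 to compound 4, that is, no movement beyond the scatter, with the measurement likely to end at a limit again. His estimate for compound 4 in this assay is 50000 nM, within 10000 nM to 100000 nM.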

Compound 4, concentration lethal to 50% of the cells: 83200 nM
Beside the measured number, compound 4's estimate is 1.7-fold (0.22 log units) below it, within the range that was stated.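

No step from compound 1 to compound 4 can be read in this assay, because compound 1 has only a limit: the limit of < 100000 nM in this assay, at which 3 of the 4 values shown sit.

The compounds shown leave open how large the change from 3,4-dichlorophenyl to 4-fluorophenyl actually is.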